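Exchanging the ring on the amide carbonyl: an expected half-life

The source may report more compounds than this note shows. Statements on the series, on what has been measured and on what is new or still open speak of the compounds shown alone.

Compound 1 `C[C@@H](NC(=O)C1(NC(=O)c2cncc(Cl)c2)CC1)c1ccc(-n2nc(Cl)c3ccccc32)cc1F`: in an in vivo ADME assay on the whole organism (strain Mongrel) for metabolic stability, with Canis familiaris (Canis lupus familiaris) as the target (on this read-out higher numbers stand for a longer-lived compound and lower numbers for a shorter-lived compound), compound 1 gives 6 h.
Compound 2 `COc1cncc(C(=O)NC2(C(=O)N[C@H](C)c3ccc(-n4nc(Cl)c5ccccc54)cc3F)CC2)c1`: in this assay compound 2 gives 2.3 h.

Going by the values given here, of the two numbers known so far, compound 2 holds the lower one; the single measured step is a 2.6-fold lower number from compound 1 to compound 2 (0.42 log units; beyond the scatter), a change of methoxy in place of chloro on an aromatic carbon. Compound 3 `COc1cc(C(=O)NC2(C(=O)N[C@H](C)c3ccc(-n4nc(Cl)c5ccccc54)cc3F)CC2)on1` carries a different kind of change: 3-methoxy-1,2-oxazol-5-yl in place of 5-methoxypyridin-3-yl on a carbonyl carbon. Here the whole ring that sits on the carbonyl carbon is exchanged, so the one measured step bears on it only loosely. It shows that a small alteration on that ring can shift this assay by a modest amount, but it says nothing about replacing the ring itself. Among the compounds with values here, with no closer precedent, no direction can be read from the data, and a shift of about the size of the usual scatter in either direction seems as likely as none at all. The expected step is therefore no change at the digits printed from compound 2 to compound 3 (within the scatter). Compound 3 is estimated at 2.3 h in this assay, within a range from 1 h to 5.5 h.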

Compound 3, half-life: 20.8 h
Compound 3: middle estimate off by 9.0-fold (0.96 log units), on the low side, and the stated range ends below it.
By their numbers in this assay, from the lowest: compound 2; then compound 1; then compound 3.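

The ring on the carbonyl carbon turns out to matter far more than the single earlier edit could suggest: 3-methoxy-1,2-oxazol-5-yl in place of 5-methoxypyridin-3-yl gives a 9.0-fold higher number from compound 2 to compound 3 (0.96 log units; beyond the scatter) in this assay. The same new ring also outperforms the chlorinated pyridine, with a 3.5-fold higher number from compound 1 to compound 3 (0.54 log units; beyond the scatter), so compound 3 goes against any reading of the earlier step, a 2.6-fold lower number from compound 1 to compound 2 (0.42 log units; beyond the scatter), as a general penalty for methoxy, since it carries a methoxy group and still holds the highest number of the three. No measurement at hand explains why exchanging this ring lengthens the half-life so strongly.

As far as these compounds go, it remains open whether the gain belongs to the five-membered ring itself or to that ring together with its methoxy group, a question that a 1,2-oxazole bearing a methyl group or a chlorine atom in place of the methoxy could help to settle. Whether other five-membered rings, such as a thiazole or a pyrazole, would behave in the same way on this carbonyl carbon is equally unknown from these three compounds.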